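Side-chain swap on the shared core: compound 3

A few compounds are considered here, and "the series" means these few. Any claim that something is new, unique, unknown or untested is made for them only; others in the source may bear on it.

Compound 1 `NCc1cccc(CN(C[C@H]2Cc3ccccc3CN2)[C@H]2CCCc3cccnc32)c1` shows in a functional assay on cells for agonist activity at C-X-C chemokine receptor type 4 (Homo sapiens), read by fluorescence and calcium flux, with a stated time of 90 s (on this read-out lower numbers stand for an effect already at smaller amounts and higher numbers for an effect only at larger amounts of compound), only a limit of the assay, > 30000 nM. Compound 2 `CC(C)(CCN)CN(C[C@H]1Cc2ccccc2CN1)[C@H]1CCCc2cccnc21` likewise shows only a limit in this assay, > 30000 nM. Hence a step that the two limits leave unreadable from compound 1 to compound 2; all that stands is the limit of > 30000 nM in this assay, at which 2 of the 2 values shown sit. Compound 3 `C(=C/CN(C[C@H]1Cc2ccccc2CN1)[C@H]1CCCc2cccnc21)\CNC1CCOCC1` carries a group of 10 heavy atoms (8 carbon, 1 nitrogen, 1 oxygen; one six-membered non-aromatic ring with 1 hetero atom) in place of a group of 6 heavy atoms (5 carbon, 1 nitrogen; no ring), on a saturated chain carbon bound to an amine nitrogen. Going by the values given here, no measured step gives a readable size, so neither direction nor magnitude can be drawn from the earlier change. Compound 3 is therefore expected to remain near the limit seen for compound 2, with a wide range of uncertainty. The expected step is a number no higher from compound 2 to compound 3 (the limit leaves the size open). Compound 3 is estimated at 30000 nM, within 3000 nM to 100000 nM.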

Compound 3, half-maximal effective concentration: > 30000 nM
Compound 3 ended at the assay's limit (the forecaster's own chance of this, stated with the estimate: 70%); the middle value lies on the limit itself.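

No step can be read among compound 1, compound 2 and compound 3 in this assay, since each value is only a limit of the assay: the limit of > 30000 nM in this assay, at which 3 of the 3 values shown sit.

Going by these compounds, whether any side chain on the shared core gives a measurable response in this assay stays open.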